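Pyrrolidin-1-yl in Place of Ethylamino on the Carbonyl Carbon

A few compounds are considered here, and "the series" means these few. Any claim that something is new, unique, unknown or untested is made for them only; others in the source may bear on it.

Going by the values given here, compound 1 `CCNC(=O)/C=C/C=C/[C@H](O)Cc1ccc(OC)c(OC)c1` supplies one of the two numbers so far in a functional assay on A549 cells (Homo sapiens) for antiproliferative activity, read by sulforhodamine B assay, with a stated time of 48 h (a lower number here means a stronger inhibitor, a higher number a weaker inhibitor), where compound 1 gives 13800 nM. Its companion compound 2 `COc1ccc(C[C@@H](O)/C=C/C=C/C(=O)NCc2cc(OC)c(OC)c(OC)c2)cc1OC` gives 19200 nM in this assay, a gap within the usual scatter, so the two cannot be told apart. Compound 3 `COc1ccc(C[C@@H](O)/C=C/C=C/C(=O)N2CCCC2)cc1OC` has not yet been measured; it differs from compound 1 by pyrrolidin-1-yl in place of ethylamino on a carbonyl carbon. Among the compounds with values here, no step between measured compounds is available, so the weight of this change cannot be read from the data. The step of a 1.2-fold higher number from compound 1 to compound 3 (0.06 log units; within the scatter) is expected to be small, at most barely beyond the scatter. Compound 3 is accordingly estimated at 16000 nM, between 5000 nM and 50000 nM.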

Compound 3, half-maximal inhibitory concentration: 24400 nM
Compound 3: middle estimate off by 1.5-fold (0.18 log units), on the low side; low and high end bracket the measured number.
By their numbers in this assay, from the lowest: compounds 1, 2 and 3 (each within the scatter of the next).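

In this assay, going by these compounds alone, the step of a 1.8-fold higher number from compound 1 to compound 3 (0.25 log units; within the scatter) gives the first reading at this position, and compound 1 and compound 3 cannot be told apart. On this carbonyl carbon, then, the amide hydrogen can give way to a closed five-membered ring without a change beyond the scatter. No measurement here explains this result.

Still open, going by these compounds, is whether a piperidin-1-yl group, a morpholin-4-yl group or a longer chain on this carbonyl carbon would move the number beyond the scatter. On these data alone, a carboxylic acid in place of the amide also remains open.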